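A few compounds are considered here, and "the series" means these few. Any claim that something is new, unique, unknown or untested is made for them only; others in the source may bear on it.

Working notes on the series. The shared core is seen in compound 1 `CCc1csc(CN[C@@H]2C[C@H]3C[C@@H]([C@H]2C)C3(C)C)c1`, in which a secondary amine links the bicyclic part to a methylene-bearing five-membered aromatic ring. In an ADME assay on MDCK cells (Canis lupus familiaris) for cytotoxicity, read by microscopy, with a stated time of 48 h (on this read-out lower numbers stand for higher toxicity in this test and higher numbers for lower toxicity in this test), compound 1 gives 25000 nM. Compound 2 `CCc1ccc(CN[C@@H]2C[C@H]3C[C@@H]([C@H]2C)C3(C)C)s1` gives 1560 nM in this assay. Compound 3 `C[C@H]1[C@H](NCc2cncs2)C[C@H]2C[C@@H]1C2(C)C` in this assay sits at > 100000 nM, which is a limit of the measurement and not a number; it is the limit of > 100000 nM in this assay, at which 1 of the 3 values shown sits. Among the two numbers shown, compound 1 stands highest, and the gap down to compound 2 lies beyond the usual scatter. For the measured compounds named here, no pair of measured compounds differs in only one place, so no measured step is available.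

Compound 4 `C[C@H]1[C@H](NCc2cc(C3CCCCC3)cs2)C[C@H]2C[C@@H]1C2(C)C` differs from compound 1 by cyclohexyl in place of ethyl on an aromatic carbon. Without a measured step of this kind to lean on, the expected step from compound 1 to compound 4 is a 3.1-fold lower number from compound 1 to compound 4 (0.49 log units; beyond the scatter), towards a lower number and beyond the scatter. Compound 4 is accordingly estimated at 8000 nM, with a range from 2000 nM to 30000 nM.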

Compound 4, minimum cytotoxic concentration: 780 nM
Estimate against measurement, compound 4: 10-fold (1.01 log units) above, outside the stated range (below it).
By their numbers in this assay, from the lowest: compounds 4 and 2 (each within the scatter of the next); then compound 1. At a limit, above all of these: compound 3.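

For the compounds shown here, with cyclohexyl in place of ethyl on an aromatic carbon, two ring bonds from the ring sulfur, this assay shows a 32-fold lower number from compound 1 to compound 4 (1.51 log units; beyond the scatter) as the first measured step. The read-out at this position therefore depends on the group it carries, and it moves beyond the scatter on a change that adds carbon and one six-membered non-aromatic ring but no hydrogen-bond donor or acceptor. Nothing measured here gives a reason for the size of this step.

Open, on these data alone, is whether the step follows the carbon count or the ring itself, which a longer chain such as hexyl or an aromatic phenyl ring at the same place would help to separate. Also open, as far as these compounds go, is how far an amine or a carboxylic acid on the cyclohexyl ring would move the value.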